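Triazole-linked flavanone: benzyl substituent widened with a nitrile

A few compounds are considered here, and "the series" means these few. Any claim that something is new, unique, unknown or untested is made for them only; others in the source may bear on it.

In a functional assay on RAW264.7 cells (Mus musculus) for inhibition, read by Griess assay, with stated times of 2 h and 24 h (a higher number here means a weaker inhibitor, a lower number a stronger inhibitor), compound 1 `COc1ccc([C@@H]2CC(=O)c3c(O)cc(OCc4cn(Cc5ccccc5)nn4)cc3O2)cc1O` gives 11000 nM and compound 2 `COc1ccc([C@@H]2CC(=O)c3c(O)cc(OCc4cn(CC5CC5)nn4)cc3O2)cc1O` gives 11900 nM. Among the compounds with values here, compound 2 thus carries the highest of the two numbers recorded so far, but its only neighbour is compound 1, and a 1.1-fold higher number from compound 1 to compound 2 (0.03 log units; within the scatter) shows that this gap lies within the scatter, so the two cannot be ordered. Within the data shown here, that step, cyclopropyl in place of phenyl on the saturated chain carbon bound to the aromatic nitrogen, is the single measured step that touches the same position.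

Compound 3 `COc1ccc([C@@H]2CC(=O)c3c(O)cc(OCc4cn(Cc5ccccc5C#N)nn4)cc3O2)cc1O` has not been measured. It differs from compound 2 as follows: 2-cyanophenyl in place of cyclopropyl on a saturated chain carbon bound to an aromatic nitrogen. The change therefore reverts toward the phenyl ring of compound 1 and adds a nitrile to it. Among the measured compounds shown here, since the exchange of phenyl for cyclopropyl was without effect beyond the scatter, the return to an aromatic ring is expected to leave the number about where compound 2 stands, and nothing among the measured compounds speaks for the nitrile itself. The step of a 1.1-fold lower number from compound 2 to compound 3 (0.03 log units; within the scatter) is therefore expected to be small. Compound 3 is estimated at 11000 nM, within 5000 nM to 25000 nM.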

Compound 3, half-maximal inhibitory concentration: 14600 nM
Compound 3: the middle estimate sits 1.3-fold (0.12 log units) below what was measured, and the stated range covers the measured number.
By their numbers in this assay, from the lowest: compounds 1, 2 and 3 (each within the scatter of the next).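

In this assay, cyano in place of hydrogen on an aromatic carbon gives a 1.3-fold higher number from compound 1 to compound 3 (0.12 log units; within the scatter), so the first substituent seen on this aromatic ring leaves the number within the scatter. Within the data shown here, the larger exchange, 2-cyanophenyl in place of cyclopropyl, gives a 1.2-fold higher number from compound 2 to compound 3 (0.09 log units; within the scatter), which means that a group of 8 heavy atoms with a hydrogen-bond acceptor and a group of 3 heavy atoms without one cannot be told apart here, and no step among the three compounds at this position lies beyond the scatter. No independent measurement is available to account for this flat picture.

From the compounds shown here alone, all three compounds share the same core and differ only in the group on the saturated chain carbon bound to an aromatic nitrogen, so what the rest of the molecule contributes stays open. Going by these compounds, it also remains open whether an amine or a carboxylic acid on the aromatic ring, a nitrile on another ring carbon, or a longer chain in place of the cyclopropylmethyl group would move the number beyond the scatter.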